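Swapping Methyl for Fluoro on the Aromatic Ring

A few compounds are considered here, and "the series" means these few. Any claim that something is new, unique, unknown or untested is made for them only; others in the source may bear on it.

Compound 1 `COc1ccc(-c2nc3cc(F)ccc3s2)cc1` gives 490 nM
Compound 2 `COc1ccc(-c2nc3cc(F)ccc3s2)cc1C` gives 48 nM
Compound 3 `COc1ccc(-c2nc3cc(F)ccc3s2)cc1F` has not yet been measured

Among the measured compounds shown here, in a functional assay on MCF7 cells (Homo sapiens) for antiproliferative activity (a lower number here means a stronger inhibitor of growth, a higher number a weaker inhibitor of growth), compound 2 gives 48 nM and holds the lower of the two numbers so far. The next structure keeps everything except one group, with fluoro in place of methyl on an aromatic carbon. For the measured compounds named here, only one measured step bears on this place: a 10-fold lower number from compound 1 to compound 2 (1.01 log units; beyond the scatter) is large and beyond the scatter, and it comes from methyl in place of hydrogen. Going by the values given here, no fluoro compound has been measured here, so how much of that drop survives the swap is unknown. A partial loss seems likely, smaller than that large step. The expected change is a 2.5-fold higher number from compound 2 to compound 3 (0.40 log units; beyond the scatter) and it points to a higher number. For compound 3 the estimated value is 120 nM (expected range 20 nM to 500 nM).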

Compound 3, concentration for 50% growth inhibition: 870 nM
For compound 3 the middle estimate is 7.3-fold (0.86 log units) below the measured one; the measured number lies above the stated range.
By their numbers in this assay, from the lowest: compound 2; then compounds 1 and 3 (each within the scatter of the next).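

In this assay the drop seen with methyl does not carry over to fluoro: this swap gives an 18-fold higher number from compound 2 to compound 3 (1.26 log units; beyond the scatter) and wipes out the gain. Fluoro in place of hydrogen gives a 1.8-fold higher number from compound 1 to compound 3 (0.25 log units; within the scatter) and stays within the scatter, so at this place fluoro cannot be told apart from hydrogen, and the gain so far belongs to methyl alone rather than to any replacement of hydrogen. Nothing available here explains why these two single-atom groups differ so sharply.

Going by these compounds, whether ethyl, chloro or an amine on this aromatic carbon, ortho to a methoxy group, would behave like methyl or like fluoro remains open. On these data alone, it is also open whether the gain from methyl would hold with anything other than the fluoro-bearing core shared by these compounds.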